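Notes on the step from compound 1 to compound 4

The compounds below may be only part of what the source reports. "The series", "measured", "known", "first", "only" and "open" are said of these compounds alone.

Within the data shown here, compound 1 `Cc1c(C)c2c(c(C)c1N)CC(C)(C)O2` holds the lowest of the three numbers measured so far: in a functional assay on the whole organism with Mus musculus as the target (on this read-out higher numbers stand for an effect only at larger amounts of compound and lower numbers for an effect already at smaller amounts), compound 1 gives 7.8 mg/kg. Compound 2 `Cc1c(C)c2c(c(C)c1N)CC(C)(CSc1ccncc1)O2` gives 19.9 mg/kg, and compound 3 `Cc1c(C)c2c(c(C)c1N)C(c1cccnc1)C(C)(C)O2` gives 32.1 mg/kg. Both departures from compound 1 add an aromatic ring to the shared core, and both raise the number beyond the scatter: a 2.6-fold higher number from compound 1 to compound 2 (0.41 log units; beyond the scatter) and a 4.1-fold higher number from compound 1 to compound 3 (0.61 log units; beyond the scatter).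

Compound 4 `Cc1c(C)c2c(c(C)c1Nc1ccccc1)CC(C)(C)O2` differs from compound 1 by phenyl in place of hydrogen on a nitrogen on an aromatic ring. Among the measured compounds shown here, no measured step touches this nitrogen, so the two steps above bear only indirectly, as the only examples of an added aromatic ring on this core; each gave a modest rise. On that basis a modest rise is expected in this assay as well, about a 2.3-fold higher number from compound 1 to compound 4 (0.36 log units; beyond the scatter). Compound 4 is therefore estimated to give 18 mg/kg, within a range from 7 mg/kg to 45 mg/kg. The range is kept wide: neither a 2.6-fold higher number from compound 1 to compound 2 (0.41 log units; beyond the scatter) nor a 4.1-fold higher number from compound 1 to compound 3 (0.61 log units; beyond the scatter) involves the nitrogen, and a step within the scatter cannot be ruled out.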

Compound 4, dose for 50% inhibition: > 50 mg/kg
Compound 4: only a limit was reported (the forecaster's own chance of this, stated with the estimate: 5%); middle value at least 2.7-fold (0.44 log units) from the limit.
By their numbers in this assay, from the lowest: compound 1; then compounds 2 and 3 (each within the scatter of the next). At a limit, above all of these: compound 4.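

Among these compounds, compound 4 is the first case of a change on the nitrogen on an aromatic ring, and in this assay amino to anilino gives an at least 6.4-fold higher number from compound 1 to compound 4 (0.80 log units; beyond the scatter). The reported value for compound 4 is a limit and not a number: the limit of > 50 mg/kg in this assay, at which 1 of the 4 values shown sits. Of the three places on the shared core that carry an added aromatic ring, this nitrogen gives the largest rise in the number, and compounds 2 and 3 stay below the limit of compound 4, so the effect of an added aromatic ring depends on where it sits in these compounds.

From the compounds shown here alone, whether the rise follows the phenyl ring itself or any replacement of hydrogen on this nitrogen remains open. A methyl or acetyl group on the nitrogen would separate these two readings, as would a pyridin-3-yl ring there.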